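The compounds below may be only part of what the source reports. "The series", "measured", "known", "first", "only" and "open" are said of these compounds alone.

Measured compounds:
- Compound 1, `COc1ccc2[nH]cc(C(=O)/C(C#N)=C/C=C(\Cl)c3ccc(OC)c(OC)c3)c2c1`: "not determined" (no result reported) in an ADME assay on Vero cells (Chlorocebus sabaeus) for cytotoxicity, read by sulforhodamine B assay, with a stated time of 48 h; a higher number here means a weaker inhibitor of growth, a lower number a stronger inhibitor of growth
- Compound 2, `COc1cc(/C(Cl)=C/C=C(\C#N)C(=O)c2c[nH]c3ccc(Br)cc23)cc(OC)c1OC`: 7600 nM

Among the compounds with values here, compound 2 is the only compound of the set with a number in this assay; compound 1 shares much of its build but has no result reported, so it gives no point of comparison. Within the data shown here, compound 2 therefore stands alone, and there is no measured step from which to read the effect of any structural change.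

Compound 3, `COc1ccc2[nH]cc(C(=O)/C(C#N)=C/C=C(\Cl)c3cc(OC)c(OC)c(OC)c3)c2c1`, differs from compound 2 in one place: methoxy in place of bromo on an aromatic carbon. A halogen on the fused core is swapped for a methoxy group; the rest of the molecule, including the chain and the trimethoxy-bearing ring, is unchanged. Among the measured compounds shown here, with no measured pair showing what such a swap does, the expectation rests on the change being small in size and on compound 2 giving 7600 nM. The step from compound 2 to compound 3 is expected to be modest, a 1.3-fold higher number from compound 2 to compound 3 (0.12 log units; within the scatter), likely within or only just beyond the usual scatter, tending if anything toward weaker growth inhibition. Compound 3 is therefore estimated at 10000 nM, with a plausible range from 3000 nM to 30000 nM.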

Compound 3, concentration for 50% growth inhibition: 9500 nM
Estimate against measurement, compound 3: 1.1-fold (0.02 log units) above; the range from low to high includes it.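

In this assay, within the data shown here, the swap of bromo for methoxy on this aromatic carbon of the shared core gives a 1.3-fold higher number from compound 2 to compound 3 (0.10 log units; within the scatter) and provides the first measured comparison in this set, since until now a single number stood alone. At this position, meta to a fused ring and para to a fused ring, a one-atom halogen and a two-atom methoxy group, which adds one hydrogen-bond acceptor by count, therefore give values that cannot be told apart in this cell test. Nothing measured here explains this result, and a single pair cannot show whether the position is generally tolerant of substitution.

Compound 1 gives "not determined" (no result reported) and so offers no comparison with compound 3 , leaving open what the methoxy groups on the ring at the far end of the chain contribute to growth inhibition. Going by these compounds, it also remains open whether a very different group at the position studied here, such as an amine or a carboxylic acid, would stay as close to these two compounds.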